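Moving the ring attachment on the sulfonamide nitrogen

This account rests on a few compounds, and the source may have more. Where it says the series, first, only, none or still open, it means among the compounds named here.

Of the compounds shown here, three have been measured in an assay on HEK293 cells for inhibition of SCN8A/SCN1B (Homo sapiens), read by patch clamp, with a stated time of 20 min; a lower number here means a stronger inhibitor, a higher number a weaker inhibitor. Compound 1 `C[C@H](Nc1ccc(S(=O)(=O)Nc2nccs2)cc1Cl)c1ccccc1` gives 130 nM. Compound 2 `C[C@H](Nc1cc(F)c(S(=O)(=O)Nc2nccs2)cc1Cl)c1ccccc1` gives 20 nM, and compound 3 `C[C@H](Nc1cc(F)c(S(=O)(=O)Nc2nccs2)cc1Cl)c1ccc(F)cc1F` gives 40 nM. Compound 2 has the lowest number of the three: the change a 6.5-fold lower number from compound 1 to compound 2 (0.81 log units; beyond the scatter) lies beyond the scatter, while the change a 2.0-fold higher number from compound 2 to compound 3 (0.30 log units; within the scatter) does not, so compound 2 and compound 3 cannot be ranked against each other.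

Compound 4 `C[C@H](Nc1cc(F)c(S(=O)(=O)Nc2cscn2)cc1Cl)c1ccccc1` is built from compound 2 by one alteration: 1,3-thiazol-4-yl in place of 1,3-thiazol-2-yl on a sulfonamide nitrogen. Neither measured step touches this part of the molecule; one concerns a fluoro on the aromatic core and the other the ring on the saturated chain carbon, so neither gives direct guidance. For compound 4 the expected step of a 2.0-fold higher number from compound 2 to compound 4 (0.30 log units; within the scatter) is therefore small, if anything a slight rise, leaning on the finding that compound 2 sits lowest with 20 nM. In this assay compound 4 is estimated at 40 nM, within a range from 10 nM to 160 nM.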

Compound 4, half-maximal inhibitory concentration: 650 nM
Beside the measured number, compound 4's estimate is 16-fold (1.21 log units) below it; the whole stated range lies below it.
By their numbers in this assay, from the lowest: compounds 2 and 3 (each within the scatter of the next); then compound 1; then compound 4.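

Both groups have the same atoms and the same counts of hydrogen-bond donors and acceptors, so only the way the ring is joined to the sulfonamide nitrogen differs. Even so, this change gives a 33-fold higher number from compound 2 to compound 4 (1.51 log units; beyond the scatter), the largest step so far in this assay. Going by these compounds alone, it is also the first step at this position, and it shows that the attachment point of the ring on the sulfonamide nitrogen can by itself change the number strongly. Nothing available here explains why this rearrangement has such an effect.

The compounds shown leave open whether the 1,3-thiazol-4-yl group would give a similar step with the 2,4-difluorophenyl group of compound 3 in place of phenyl. They also leave open how a different ring on the sulfonamide nitrogen, such as pyridin-2-yl or 1,2,4-thiadiazol-5-yl, would compare with 1,3-thiazol-2-yl.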